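Ethyl on the Ring Amide Nitrogen: What to Expect for Compound 4

A few compounds are considered here, and "the series" means these few. Any claim that something is new, unique, unknown or untested is made for them only; others in the source may bear on it.

The study concerns a small set of compounds built on a shared core and tested in a functional assay on HCT-116 cells (Homo sapiens) for inhibition, read by MTT assay, with a stated time of 48 h; on this read-out higher numbers stand for weaker inhibition and lower numbers for stronger inhibition. Compound 1, `CN1CCN(c2ccc(Nc3ncc4c(n3)N(C3CCCC3)CC(=O)N4)nc2)CC1`, carries a 4-methylpiperazin-1-yl group on an aromatic carbon. In this assay compound 1 gives > 30000 nM, which is a limit of the assay and not a number. Compound 2, `O=C1CN(C2CCCC2)c2nc(Nc3ccc(N4CCCCC4)cn3)ncc2N1`, instead bears a piperidin-1-yl group. In this assay compound 2 gives > 30000 nM, again only a limit. Compound 3, `CC1CCN(c2ccc(Nc3ncc4c(n3)N(C3CCCC3)CC(=O)N4)nc2)CC1`, bears a 4-methylpiperidin-1-yl group. In this assay compound 3 gives > 30000 nM, also a limit. All three values sit at the limit of > 30000 nM in this assay, at which 3 of the 3 values shown sit, so the steps a step that the two limits leave unreadable from compound 1 to compound 2, a step that the two limits leave unreadable from compound 1 to compound 3 and a step that the two limits leave unreadable from compound 2 to compound 3 are unreadable in both size and direction.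

Compound 4, `CCN1C(=O)CN(C2CCCC2)c2nc(Nc3ccc(N4CCCCC4)cn3)ncc21`, differs from compound 2 by ethyl in place of hydrogen on an amide-type nitrogen in a ring. The measured steps that touch compound 2 offer no readable size, and compound 2 itself stands at a limit in this assay. No step beyond the scatter can therefore be anticipated in either direction, and a limit is the most probable outcome once more. Compound 4 is expected to give 40000 nM in this assay, within a range from 10000 nM to 150000 nM. The estimated step is a step that the limit leaves unreadable from compound 2 to compound 4.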

Compound 4, half-maximal inhibitory concentration: 14500 nM
Beside the measured number, compound 4's estimate is 2.8-fold (0.44 log units) above it; measured number inside the range.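

In this assay, ethyl in place of hydrogen on the amide-type nitrogen in the ring gives an at least 2.0-fold lower number from compound 2 to compound 4 (0.31 log units; beyond the scatter), and on this read-out a lower number stands for stronger inhibition. Going by these compounds alone, this is the first step in the set that can be read at all, since the steps among compound 1, compound 2 and compound 3 cannot, and it shows that this ring nitrogen is a place where a change moves the read-out: the amide hydrogen can be replaced by a two-carbon chain with the value of compound 4 coming to rest on a measured number. Compound 4 is also the only compound shown that stands off the shared limit: the limit of > 30000 nM in this assay, at which 3 of the 4 values shown sit.

Because only one substituent has been shown at this nitrogen, it remains open whether methyl, a longer chain such as propyl or butyl, or a chain ending in an amine or a carboxylic acid would take the number further down or back to the limit. From the compounds shown here alone, it also remains open whether ethyl at this place would have the same effect with the 4-methylpiperazin-1-yl group of compound 1 or the 4-methylpiperidin-1-yl group of compound 3.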